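Efficacy in the series: cyclic amidine replacing the thiocarbonyl group

The source may report more compounds than this note shows. Statements on the series, on what has been measured and on what is new or still open speak of the compounds shown alone.

Working notes. The series rests on a shared core, seen in compound 1 `CCSC(=O)N1CCC(Oc2ncnc3c2CCN3c2ccc(S(C)(=O)=O)cc2F)CC1`; in a functional assay on CHO-K1 cells with Glucose-dependent insulinotropic receptor (Homo sapiens) as the target, read by a luciferase reporter, with a stated time of 5 h (a lower number here means a smaller maximal response, a higher number a larger maximal response), compound 1 gives 128%. Compound 2 `CC(C)SC(=O)N1CCC(Oc2ncnc3c2CCN3c2ccc(S(C)(=O)=O)cc2F)CC1` differs only by the methyl in place of hydrogen on a saturated chain carbon bound to a saturated chain carbon and a sulfur; in this assay compound 2 gives 138%, and the step of a number 10 percentage points higher from compound 1 to compound 2 (within the scatter) leaves the two compounds within the scatter of each other, so compound 2 stands alongside compound 1 with no separation on the numbers shown.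

Compound 3 `CS(=O)(=O)c1ccc(N2CCc3c(OC4CCN(C5=NCCCN5)CC4)ncnc32)c(F)c1` carries a different change: a group of 6 heavy atoms (4 carbon, 2 nitrogen; one six-membered non-aromatic ring with 2 hetero atoms) in place of a group of 6 heavy atoms (4 carbon, 1 oxygen, 1 sulfur; no ring), on an amine nitrogen in a ring. Within the data shown here, the one measured step, from compound 1 to compound 2, concerns a methyl on the chain and does not bear on an exchange of the whole group on the amine nitrogen; no measured pair informs this change. The step of a number 13 percentage points lower from compound 2 to compound 3 (beyond the scatter) is therefore expected to be small and of uncertain direction. For compound 3 in this assay the expected value is 125%, with a range from 85% to 160%.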

Compound 3, largest response reached (reported as percent of maximum), in percent of the reference or control that the assay uses: 66%
Estimate against measurement, compound 3: 59 percentage points above; measured number below the stated range.
By their numbers in this assay, from the lowest: compound 3; then compounds 1 and 2 (each within the scatter of the next).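

On the amine nitrogen of the six-membered non-aromatic ring, the group can be exchanged with a large effect on the maximal response: in this assay, the ring with 2 hetero atoms in place of (isopropylsulfanyl)carbonyl gives a number 72 percentage points lower from compound 2 to compound 3 (beyond the scatter), and the same ring in place of the smaller chain of compound 1 gives a number 62 percentage points lower from compound 1 to compound 3 (beyond the scatter). The change on the chain alone had shown no such separation, with a number 10 percentage points higher from compound 1 to compound 2 (within the scatter), so replacing the whole group matters far more at this position than adding a methyl to the chain. Nothing available accounts for the drop.

From the compounds shown here alone, whether the drop follows from the ring itself or from the removal of the carbonyl and sulfur remains open. An open-chain amidine or an ethoxycarbonyl group on the same nitrogen would help to separate these two readings.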